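A few compounds are considered here, and "the series" means these few. Any claim that something is new, unique, unknown or untested is made for them only; others in the source may bear on it.

In an assay on isolated protein for inhibition of long-chain fatty acid transport protein 1 (Mus musculus), read by scintillation counting, with a stated time of 20 min (a lower number here means a stronger inhibitor, a higher number a weaker inhibitor), the measured compounds and their readings are:

compound 1, `O=C(CN1CCN(c2cccc(F)c2)CC1)Nc1nc2c(s1)CCCC2`, giving > 10000 nM;
compound 2, `CC1CCc2sc(NC(=O)CN3CCN(c4ccc(F)cc4)CC3)nc2C1`, giving 5100 nM;
compound 3, `O=C(CN1CCN(c2ccc(F)cc2)CC1)Nc1nc2c(s1)CCCCC2`, giving 2000 nM.

Compound 1 stands at the edge of what this assay reports: its reading of > 10000 nM is a limit and not a number (the limit of > 10000 nM in this assay, at which 1 of the 3 values shown sits). Among the measured compounds shown here, compound 2 and compound 3 each give a number in this assay, but both differ from compound 1 in more than one place, so they show only that numbers have been reached and offer no single step from compound 1.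

Compound 4, `O=C(CN1CCN(c2cccnc2)CC1)Nc1nc2c(s1)CCCC2`, has not yet been measured. It differs from compound 1 in one place: pyridin-3-yl in place of 3-fluorophenyl on an amine nitrogen in a ring. For the measured compounds named here, no measured pair shows the effect of such a change in this assay, so there is no ground for expecting a step in either direction beyond the scatter. Since compound 1 is known only as a limit, the size of any step from it cannot be read from the data. Compound 4 is therefore expected to sit near that limit, with an estimate of 15000 nM and a range from 4000 nM to 50000 nM. The expected step is a step that the limit leaves unreadable from compound 1 to compound 4.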

Compound 4, half-maximal inhibitory concentration: > 10000 nM
Compound 4: no number, only a limit; the forecaster's own chance of this, stated with the estimate: 60%; the middle value does not contradict the limit.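

No step can be read from compound 1 to compound 4, since in this assay each of the two is known only as a limit and not as a number: the limit of > 10000 nM in this assay, at which 2 of the 4 values shown sit.

The compounds shown leave open whether pyridin-3-yl in place of 3-fluorophenyl on an amine nitrogen in a ring changes the reading at all, and in which direction.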